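The source may report more compounds than this note shows. Statements on the series, on what has been measured and on what is new or still open speak of the compounds shown alone.

Three esters of the shared core have been read in an ADME assay on HEp-2 cells (Homo sapiens) for cytotoxicity, read by MTT assay, with a stated time of 24 h; on this read-out lower numbers stand for higher toxicity in this test and higher numbers for lower toxicity in this test. Compound 1 `CCCOC(=O)CCc1ccc(O)c(O)c1` gives > 200 ug/mL in this assay, which is a limit and not a number. Compound 2 `CCCCOC(=O)CCc1ccc(O)c(O)c1` gives 200 ug/mL in this assay, and compound 3 `CC(=O)OCCc1ccc(O)c(O)c1` gives 50 ug/mL, the lowest of the two numbers, set apart from compound 2 by a gap beyond the scatter. For the measured compounds named here, the single measured step, a number no higher from compound 1 to compound 2 (the limit leaves the size open), shows no rise; its size stays hidden because of the limit of > 200 ug/mL in this assay, at which 1 of the 3 values shown sits. Compound 4 `CCCCC(=O)OCCc1ccc(O)c(O)c1` is not yet measured and differs from compound 3 by propyl in place of hydrogen on a saturated chain carbon bound to a carbonyl carbon. The measured step sits on a different saturated chain carbon, so it bears on this change only loosely and points to no rise. For compound 4 the step of a 1.3-fold lower number from compound 3 to compound 4 (0.10 log units; within the scatter) is expected, within the scatter. Compound 4 is estimated at 40 ug/mL, between 15 ug/mL and 110 ug/mL.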

Compound 4, half-maximal cytotoxic concentration: 25 ug/mL
Beside the measured number, compound 4's estimate is 1.6-fold (0.20 log units) above it, within the range that was stated.
By their numbers in this assay, from the lowest: compounds 4 and 3 (each within the scatter of the next); then compound 2.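

For the compounds shown here, on the saturated chain carbon bound to a carbonyl carbon, propyl in place of hydrogen gives the first chain step with a readable size: in this assay it reads a 2.0-fold lower number from compound 3 to compound 4 (0.30 log units; within the scatter) and so stays inside the usual scatter. Methyl to butyl at this place therefore does not separate the two compounds. The earlier chain step, on a different carbon, gave no readable size: the limit of > 200 ug/mL in this assay, at which 1 of the 4 values shown sits.

Going by these compounds, whether a longer chain, an amine or a carboxylic acid at this place would move the number beyond the scatter stays open. Also open, on these data alone, is whether the same change would read alike on the core of compound 1.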